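Removing the methylsulfanyl group from compound 2

The source may report more compounds than this note shows. Statements on the series, on what has been measured and on what is new or still open speak of the compounds shown alone.

Of the compounds shown here, three sharing one core have been measured in a functional assay on the whole organism with Rattus norvegicus as the target, with a stated time of 4 h, at a dose of 40 mg/kg by the intraperitoneal route; on this read-out lower numbers stand for less inhibition and higher numbers for more inhibition at the one dose given (going by the name of the read-out). Compound 1 `Cc1nc2c(COc3ccccc3)cccn2c1C` gives 48%. Compound 2 `CSCc1c(C)nc2c(OCc3ccccc3)cccn12` gives 29%, the lowest of the three numbers: compound 1 lies closer to it, and compound 3 furthest from it. Going by the values given here, compound 3 `Cc1nc2c(OCc3ccccc3)cccn2c1COC(=O)N(C)C` gives 75%, and the one step that has been worked out, a number 46 percentage points higher from compound 2 to compound 3 (beyond the scatter), shows that replacing the methylsulfanyl group on a saturated chain carbon bound to an aromatic carbon with a (dimethylcarbamoyl)oxy group is followed by a large rise.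

Compound 4 `Cc1nc2c(OCc3ccccc3)cccn2c1C` is not yet measured. It differs from compound 2 by hydrogen in place of methylsulfanyl on a saturated chain carbon bound to an aromatic carbon. Among the compounds with values here, no measured step removes this group outright, so the step to compound 3 is the only one that touches the same position, and it says only that changing what sits there can shift the number a long way. Compound 1, which also carries a methyl at this place but with its side chain built differently, sits at a middling value. Compound 4 is therefore expected to move upward from compound 2 by a number 16 percentage points higher from compound 2 to compound 4 (beyond the scatter), and its estimate in this assay is 45%, in the range 25% to 65%.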

Compound 4, a percentage reported as inhibition, in the whole organism at one dose (the size of the read-out at that dose, not a potency): 99%
Estimate against measurement, compound 4: 54 percentage points below, and the stated range ends below it.
By their numbers in this assay, from the lowest: compound 2; then compound 1; then compound 3; then compound 4.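

In this assay the plain methyl of compound 4 stands above both substituted forms: hydrogen in place of methylsulfanyl gives a number 70 percentage points higher from compound 2 to compound 4 (beyond the scatter) and hydrogen in place of (dimethylcarbamoyl)oxy gives a number 24 percentage points higher from compound 3 to compound 4 (beyond the scatter) on the same saturated chain carbon bound to an aromatic carbon. The large rise seen earlier on exchanging methylsulfanyl for (dimethylcarbamoyl)oxy therefore no longer reads as a gain over the unsubstituted compound: among compound 2, compound 3 and compound 4, each added group goes with a lower number than hydrogen. The two groups are not equal in this respect, for the step from methylsulfanyl is large and the step from (dimethylcarbamoyl)oxy only modest, which shows that the identity of the group matters and not merely the presence of one.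

On these data alone, whether any group on this carbon can match hydrogen remains open, and a hydroxyl, a dimethylamino group or a longer chain such as ethyl would each put that to the test. The compounds and their numbers at this one dose offer nothing that explains these differences.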